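Adding One Chloro to Compound 3

This account rests on a few compounds, and the source may have more. Where it says the series, first, only, none or still open, it means among the compounds named here.

In a functional assay on HCT-116 cells (Homo sapiens) for antiproliferative activity, read by MTT assay, with a stated time of 72 h (a lower number here means a stronger inhibitor, a higher number a weaker inhibitor), the measured compounds read as follows:
- Compound 1 `C=CS(=O)(=O)Nc1ccc(Cl)c(S(=O)(=O)N(C)C)c1` gives 9900 nM
- Compound 2 `C=CC(=O)Nc1cnn(Cc2ccccc2)c1` gives > 30000 nM (a limit of the assay, not a number)
- Compound 3 `C=CC(=O)Nc1nc(-c2ccccc2)cs1` gives 18600 nM

In this assay compound 3 stands at 18600 nM and compound 1 at 9900 nM as a pair within the usual scatter, so neither can be ranked over the other. For compound 2 there is only the limit of > 30000 nM in this assay, at which 1 of the 3 values shown sits, and no number.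

Compound 4 `C=CC(=O)Nc1nc(-c2ccccc2Cl)cs1` differs from compound 3 in one place chloro in place of hydrogen on an aromatic carbon with chloro in place of hydrogen on an aromatic carbon, ortho to a large group. Going by the values given here, no two measured compounds differ in just one place, so the data offer no direct guide to this change. A small step in this assay is expected, no larger than the scatter and with no firm direction. The estimated step is a 1.2-fold lower number from compound 3 to compound 4 (0.09 log units; within the scatter) and it could turn out either way. Compound 4 is expected at 15000 nM (expected range 6000 nM to 30000 nM).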

Compound 4, half-maximal inhibitory concentration: 12300 nM
Beside the measured number, compound 4's estimate is 1.2-fold (0.09 log units) above it; measured number inside the range.
By their numbers in this assay, from the lowest: compounds 1, 4 and 3 (each within the scatter of the next). At a limit, above all of these: compound 2.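

In this assay, going by these compounds alone, the change of chloro in place of hydrogen on an aromatic carbon, ortho to a large group, gives a 1.5-fold lower number from compound 3 to compound 4 (0.18 log units; within the scatter) and is the first single change in this set that can be read directly. It shows that this place on the six-membered aromatic ring can carry a chloro with no difference that stands clear of the usual scatter of repeated measurements, so no direction can be claimed for the change. Nothing in the data shown bears on why the two compounds read as they do.

Going by these compounds, whether an amine, a methoxy group or a carboxylic acid in this same place would give a step beyond the scatter remains open. Also open, on these data alone, is whether chloro in place of hydrogen would read the same way on the core of compound 2.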